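Chloro in place of methoxy on the shared core

This account rests on a few compounds, and the source may have more. Where it says the series, first, only, none or still open, it means among the compounds named here.

Measured so far in a functional assay on MT4 cells (Homo sapiens) for antiproliferative activity, read by MTT assay, with a stated time of 96 h; a higher number here means a weaker inhibitor, a lower number a stronger inhibitor:
compound 1 `CN(C)c1ccc(N2C(=O)NC3(CSC4=C3C(=O)c3ncccc3C4=O)C2=O)cc1`, 15 nM
compound 2 `CCCc1ccc(N2C(=O)NC3(CSC4=C3C(=O)c3ncccc3C4=O)C2=O)cc1`, 1 nM
compound 3 `COc1ccc(N2C(=O)NC3(CSC4=C3C(=O)c3ncccc3C4=O)C2=O)cc1`, 70 nM

Compound 3 has the highest number of the three: a 4.7-fold higher number from compound 1 to compound 3 (0.67 log units; beyond the scatter) and a 70-fold higher number from compound 2 to compound 3 (1.85 log units; beyond the scatter) both set it apart beyond the scatter. Compound 4 `O=C1C2=C(C(=O)c3ncccc31)C1(CS2)NC(=O)N(c2ccc(Cl)cc2)C1=O` differs from it by chloro in place of methoxy on an aromatic carbon. Going by the values given here, no measured step involves chloro, so none bears directly on this change; the steps that exist, a 15-fold lower number from compound 1 to compound 2 (1.18 log units; beyond the scatter) together with the two just named, show only that the group at that place moves the number widely. From that spread a lower number than compound 3 is expected for compound 4, a 5.8-fold lower number from compound 3 to compound 4 (0.77 log units; beyond the scatter), though with wide uncertainty. Compound 4 is therefore estimated at 12 nM, with a range from 2 nM to 70 nM.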

Compound 4, half-maximal inhibitory concentration: 10 nM
Estimate against measurement, compound 4: 1.2-fold (0.08 log units) above, within the range that was stated.
By their numbers in this assay, from the lowest: compound 2; then compounds 4 and 1 (each within the scatter of the next); then compound 3.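

In this assay chloro separates clearly from methoxy (a 7.0-fold lower number from compound 3 to compound 4 (0.85 log units; beyond the scatter)) but does not reach propyl (a 10-fold higher number from compound 2 to compound 4 (1.00 log units; beyond the scatter)), while it cannot be told apart from dimethylamino (a 1.5-fold lower number from compound 1 to compound 4 (0.18 log units; within the scatter)). Across the four groups, propyl therefore gives the lowest number and methoxy the highest, with chloro and dimethylamino together between them. No measurement is available that would explain this order. The compounds shown leave open where bromo or trifluoromethyl would fall at this place. They also leave open whether a shorter or longer chain would match propyl.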